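Swapping the anilino arm of compound 3 for a saturated amine

A few compounds are considered here, and "the series" means these few. Any claim that something is new, unique, unknown or untested is made for them only; others in the source may bear on it.

Of the compounds shown here, three sharing one core have been measured in a functional assay on NCI-H460 cells (Homo sapiens) for antiproliferative activity, read by CCK-8 assay, with a stated time of 72 h, tested at 8 uM; on this read-out lower numbers stand for a weaker effect and higher numbers for a stronger effect at the one concentration tested. Compound 1, `CN1CCN(c2nc(Cl)nc3c2ncn3Cc2ccc(C(=O)Nc3ccccc3N)cc2)CC1`, gives 55.1%. Compound 2, `Nc1ccccc1NC(=O)c1ccc(Cn2cnc3c(Nc4ccccc4)nc(Cl)nc32)cc1`, gives 77.8%, and compound 3, `Cc1ccc(Nc2nc(Cl)nc3c2ncn3Cc2ccc(C(=O)Nc3ccccc3N)cc2)cc1`, gives 82.5%. Compound 3 therefore holds the highest of the three numbers, though its margin over compound 2 is a number 4.7 percentage points higher from compound 2 to compound 3 (within the scatter), so the two cannot be ordered; its margin over compound 1 is a number 27.4 percentage points higher from compound 1 to compound 3 (beyond the scatter), which is a clear gap.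

The next compound, compound 4, `CC1CCN(c2nc(Cl)nc3c2ncn3Cc2ccc(C(=O)Nc3ccccc3N)cc2)CC1`, has not been measured. It differs from compound 3 in one place: 4-methylpiperidin-1-yl in place of (4-methylphenyl)amino on an aromatic carbon. The change brings the substituent back toward the kind seen in compound 1, a six-membered non-aromatic ring with one hetero atom and no hydrogen-bond donor, rather than the aryl-amine of compound 2 and compound 3. The measured steps that bear on it are a number 22.7 percentage points higher from compound 1 to compound 2 (beyond the scatter) and a number 27.4 percentage points higher from compound 1 to compound 3 (beyond the scatter), both modest gains when an aromatic amine replaced a saturated amine ring. A reversal of roughly that size is expected here, in the downward direction, with some allowance that 4-methylpiperidin-1-yl is not identical to 4-methylpiperazin-1-yl.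

The step expected from compound 3 to compound 4 in this assay is a number 22.5 percentage points lower from compound 3 to compound 4 (beyond the scatter). Compound 4 is thus estimated at 60%, within a range from 45% to 75%.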

Compound 4, a percentage reported as inhibition, at one concentration (the size of the read-out at that concentration, not a potency): 40.9%
Compound 4: the middle estimate sits 19.1 percentage points above what was measured; measured number below the stated range.
By their numbers in this assay, from the lowest: compound 4; then compound 1; then compounds 2 and 3 (each within the scatter of the next).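

At this aromatic carbon, the loss from an aryl amine arm to a saturated ring can be much larger than compound 1 alone had indicated: 4-methylpiperidin-1-yl gives large drops against both aryl amines (a number 41.6 percentage points lower from compound 3 to compound 4 (beyond the scatter); a number 36.9 percentage points lower from compound 2 to compound 4 (beyond the scatter)) in this assay. The saturated rings are also not interchangeable here, since exchanging 4-methylpiperazin-1-yl for 4-methylpiperidin-1-yl gives a modest step beyond the scatter (a number 14.2 percentage points lower from compound 1 to compound 4 (beyond the scatter)), so the outcome depends on which ring is present, not only on the absence of the aromatic arm. No measurement available here explains either the large drops or the difference between the two saturated rings.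

The aryl amines differ from both saturated rings in having the amine hydrogen and the aromatic ring together, so the compounds shown cannot separate these two features; an N-methylanilino group, with the aromatic ring but no amine hydrogen, and a cyclohexylamino group, with the amine hydrogen but no aromatic ring, would pull them apart. From the compounds shown here alone, how a morpholin-4-yl group would rank against the two saturated rings also remains open.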